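Three Compounds at the Assay Limit and a Fourth Estimated

The source may report more compounds than this note shows. Statements on the series, on what has been measured and on what is new or still open speak of the compounds shown alone.

Compound 1 `COc1cc2c(cc1OC)CN(CCn1cc(COc3cccc4ccccc34)nn1)CC2` gives > 100000 nM in an ADME assay on K562/A02 cells (Homo sapiens) for cytotoxicity, read by MTT assay, with a stated time of 48 h (on this read-out lower numbers stand for stronger inhibition and higher numbers for weaker inhibition), which is a limit of the assay.
Compound 2 `COc1cc2c(cc1OC)CN(CCn1cc(COc3ccc(C)cc3)nn1)CC2` gives > 100000 nM in this assay, again a limit.
Compound 3 `COc1cc2c(cc1OC)CN(CCn1cc(COc3ccc(C)c(C)c3)nn1)CC2` gives > 100000 nM in this assay, again a limit.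

Among the compounds with values here, compound 1 therefore stands only at a limit, and none of the measured steps can be sized: a step that the two limits leave unreadable from compound 1 to compound 2, a step that the two limits leave unreadable from compound 1 to compound 3 and a step that the two limits leave unreadable from compound 2 to compound 3. All three values sit at one point, (the limit of > 100000 nM in this assay, at which 3 of the 3 values shown sit). Compound 4 `COc1cc2c(cc1OC)CN(CCn1cc(COc3ccccc3C(C)(C)C)nn1)CC2` differs from compound 1 in one place: 2-(tert-butyl)phenyl in place of naphthalen-1-yl on an oxygen on a saturated carbon. With no readable step to lean on, no shift beyond the scatter is expected in this assay, and the estimate rests on the limit shown for compound 1 (> 100000 nM). The expected step is a step that the limit leaves unreadable from compound 1 to compound 4. Compound 4 is estimated at 150000 nM (70000 nM to 400000 nM), most likely reported as a limit once more.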

Compound 4, half-maximal inhibitory concentration: > 100000 nM
Compound 4: only a limit was reported (the forecaster's own chance of this, stated with the estimate: 85%); the middle value does not contradict the limit.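

Compound 4, like compound 1, compound 2 and compound 3, stands only at a limit in this assay and no new step can be read. The compounds shown leave open whether any group in this place gives a readable value.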